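Sulfonyl substituent exchange on the aryl-alkyne phenoxyacetic acid series

The source may hold more compounds than are shown below. What is called first, only, known or untested is meant among the compounds shown, and "the series" means these compounds.

Three measured compounds share the core of compound 1 `Cc1ccc(S(=O)(=O)CCO)cc1C#Cc1cc(Cl)ccc1OCC(=O)O`. In an assay on CHO cells for displacement of a labelled ligand from prostaglandin D2 receptor 2 (Homo sapiens), read by scintillation counting (on this read-out lower numbers stand for stronger inhibition and higher numbers for weaker inhibition), compound 1 gives 19 nM, which is the lowest of the three numbers. Compound 3 `N#Cc1ccc(OCC(=O)O)c(C#Cc2ccccc2Cl)c1` gives 24 nM, a number that sits within the scatter of compound 1, so the two cannot be ordered. Compound 2 `CN(C)C(=O)c1ccc(C#Cc2cc(Cl)ccc2OCC(=O)O)cc1` gives 55 nM, a number that lies beyond the scatter from compound 1.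

Compound 4 `Cc1ccc(S(=O)(=O)N(C)CCN(C)C)cc1C#Cc1cc(Cl)ccc1OCC(=O)O` is not yet measured. It differs from compound 1 in one place:

(2-(dimethylamino)ethyl)(methyl)amino in place of 2-hydroxyethyl on a sulfonyl sulfur

Among the measured compounds shown here, no pair of measured compounds shows this or a comparable exchange on the sulfonyl sulfur, so nothing measured here speaks to its size. The change keeps the acid, the alkyne and the substituted aryl rings of compound 1 unchanged, and the exchanged groups both carry one hydrogen-bond acceptor. The expectation is therefore a small step from compound 1 to compound 4 of a 1.6-fold higher number from compound 1 to compound 4 (0.20 log units; within the scatter), inside or close to the scatter, with no firm direction. Compound 4 is estimated at 30 nM in this assay, with a range of 8 nM to 120 nM.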

Compound 4, inhibition constant: 369 nM
Compound 4: the middle estimate sits 12-fold (1.09 log units) below what was measured; the whole stated range lies below it.
By their numbers in this assay, from the lowest: compounds 1 and 3 (each within the scatter of the next); then compound 2; then compound 4.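

On a sulfonyl sulfur, this position does not tolerate every exchange. In this assay, among the compounds shown here, the change from 2-hydroxyethyl to (2-(dimethylamino)ethyl)(methyl)amino gives a 19-fold higher number from compound 1 to compound 4 (1.29 log units; beyond the scatter) while the rest of the core of compound 1 stays the same, so the group on the sulfur can strongly affect this read-out, which the earlier compounds could not show. No measurement here accounts for the size of this step.

The exchange alters the atom bound to the sulfur, the chain and its end group in one move, so the compounds shown do not reveal which of these carries the step. A plain dimethylamino on the sulfonyl sulfur, or a 2-hydroxyethylamino group, would separate the sulfonamide link from the terminal amine.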